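A few compounds are considered here, and "the series" means these few. Any claim that something is new, unique, unknown or untested is made for them only; others in the source may bear on it.

Measured compounds:
compound 1 `CCN(CC)c1ccc(/C=C/C(=O)c2ccc(OC)c3c2OC(C)(C)C=C3)cc1`: 670 nM
compound 2 `COc1ccc(C(=O)/C=C/c2ccc(Cl)cc2)c2c1C=CC(C)(C)O2`: > 10000 nM
compound 3 `COc1ccc(C(=O)/C=C/c2cccc(Cl)c2)c2c1C=CC(C)(C)O2`: > 10000 nM

Among the measured compounds shown here, in a functional assay on SW-620 cells (Homo sapiens) for antiproliferative activity, read by MTT assay, with a stated time of 24 h (on this read-out lower numbers stand for stronger inhibition and higher numbers for weaker inhibition), compound 1 gives 670 nM, the only number among the three values shown. For compound 2 this assay reports only a limit, > 10000 nM. For compound 3 it likewise reports only a limit, > 10000 nM. The step of an at least 14-fold higher number from compound 1 to compound 2 (1.17 log units; beyond the scatter) is large, while the step that the two limits leave unreadable from compound 2 to compound 3 cannot be read because both values sit at the limit of > 10000 nM in this assay, at which 2 of the 3 values shown sit. Compound 4 `COc1ccc(C(=O)/C=C/c2ccc(O)cc2)c2c1C=CC(C)(C)O2` differs from compound 1 by hydroxy in place of diethylamino on an aromatic carbon. For the measured compounds named here, the step from compound 1 to compound 2, the only measured change at this position, is the one that bears on it. Hydroxy is neither diethylamino nor chloro, so a loss is expected, a 4.5-fold higher number from compound 1 to compound 4 (0.65 log units; beyond the scatter), with the limit a live possibility. Compound 4 is expected at 3000 nM, between 800 nM and 10000 nM.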

Compound 4, half-maximal inhibitory concentration: > 10000 nM
Compound 4: only a limit was reported; the forecaster's own chance of this, stated with the estimate: 35%; middle value at least 3.3-fold (0.52 log units) away from the limit.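

In this assay, hydroxy in place of diethylamino gives an at least 14-fold higher number from compound 1 to compound 4 (1.17 log units; beyond the scatter) and so, after chloro, is a second replacement at this position that does not keep the number of compound 1. Of the compounds shown, only compound 1, with diethylamino, gives a number rather than a limit. The steps among compound 2, compound 3 and compound 4 cannot be read, since all three values are limits: the limit of > 10000 nM in this assay, at which 3 of the 4 values shown sit.

Going by these compounds, whether a smaller amine such as dimethylamino, or a pyrrolidine ring, would keep a measurable number remains open. Hydroxy and chloro also cannot be ranked against each other.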